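This account rests on a few compounds, and the source may have more. Where it says the series, first, only, none or still open, it means among the compounds named here.

For the measured compounds named here, in an ADME assay on CHO cells (Cricetulus griseus) for cytotoxicity, read by MTT assay (a higher number here means that more compound is tolerated, a lower number that less compound is tolerated), compound 2 (`CN1CCN(C2CCN(c3nccc4[nH]c(-c5ccc(F)c(F)c5)nc34)CC2)CC1`) gives 5000 nM as the lower of the two numbers measured so far. The other measured compound, compound 1 (`Fc1ccc(-c2nc3c(N4CCN5CCCC5C4)nccc3[nH]2)cc1F`), gives 32000 nM and so is better tolerated by a margin beyond the usual scatter of repeats. These two compounds do not differ in just one place, so their gap cannot be tied to any single change.

Compound 3 (`CN1CCN(C(=O)C2CCN(c3nccc4[nH]c(-c5ccc(F)c(F)c5)nc34)CC2)CC1`) keeps the shared core of compound 2 and alters one group. It has (4-methylpiperazin-1-yl)carbonyl in place of 4-methylpiperazin-1-yl on a saturated ring carbon. Going by the values given here, no measured pair shows this change, so any forecast rests on thin evidence. Among the compounds with values here, compound 1 at 32000 nM shows only that the shared core can carry a number well above that of compound 2. A modest upward move is expected, meaning that slightly more of the compound should be tolerated, though it may not clear the scatter. The expected step is a 2.2-fold higher number from compound 2 to compound 3 (0.34 log units; beyond the scatter) in this assay and is uncertain in size. For compound 3 the estimated value is 11000 nM, with a range from 3500 nM to 32000 nM.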

Compound 3, half-maximal cytotoxic concentration: > 50000 nM
Compound 3: no number, only a limit (the forecaster's own chance of this, stated with the estimate: 10%); middle value at least 4.5-fold (0.65 log units) away from the limit.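

In this assay compound 3 gives > 50000 nM, which is a limit of the assay and not a number. Replacing 4-methylpiperazin-1-yl with (4-methylpiperazin-1-yl)carbonyl on this saturated ring carbon gives an at least 10-fold higher number from compound 2 to compound 3 (1.00 log units; beyond the scatter), the first gap here that can be tied to a single change, and it shows that a group at this place, three ring bonds from the ring nitrogen, can shift the tolerated concentration well beyond the scatter of repeat measurements. The full size of this step cannot be read, because the reading ends at a limit: the limit of > 50000 nM in this assay, at which 1 of the 3 values shown sits.

This single pair cannot separate the part played by the carbonyl from that of the whole group that enters, and a carboxylic acid or a simple primary amide on the same ring carbon would be needed to tell whether the methylpiperazine ring matters at all. For the compounds shown here, it also remains open whether the same change would give a step of similar direction on any other compound, for only one pair carries it so far.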